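From a Hydroxysulfamoyl Chain to a Dimethylsulfamoyl Chain

A few compounds are considered here, and "the series" means these few. Any claim that something is new, unique, unknown or untested is made for them only; others in the source may bear on it.

Of the compounds shown here, three sharing one core have been tested in an assay on HeLa cells for inhibition of Indoleamine 2,3-dioxygenase 1 (Homo sapiens), read by spectrophotometry, with a stated time of 24 h; on this read-out higher numbers stand for an effect only at larger amounts of compound and lower numbers for an effect already at smaller amounts. Compound 1 `NNc1nonc1/C(=N/O)Nc1ccc(F)c(Br)c1` gives 556 nM in this assay. Compound 2 `[O-][S+]1CC(Nc2nonc2/C(=N/O)Nc2ccc(F)c(Br)c2)C1` gives 79 nM, and the change a 7.0-fold lower number from compound 1 to compound 2 (0.85 log units; beyond the scatter) is the one clear gain among the three. Compound 3 `O=S(=O)(CCNc1nonc1/C(=N/O)Nc1ccc(F)c(Br)c1)NO` reaches only a limit in this assay, > 800 nM, not a number; its place among the three is told by the limit of > 800 nM in this assay, at which 1 of the 3 values shown sits. Within the data shown here, the steps of an at least 1.4-fold higher number from compound 1 to compound 3 (0.15 log units; that floor lies within the scatter) and an at least 10-fold higher number from compound 2 to compound 3 (1.00 log units; beyond the scatter) therefore say only that compound 3 sits at the weak end of what has been measured.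

Compound 4 `CN(C)S(=O)(=O)CCCNc1nonc1/C(=N/O)Nc1ccc(F)c(Br)c1` keeps that weak starting point and changes the chain: (dimethylsulfamoyl)methyl in place of hydroxysulfamoyl on a saturated chain carbon, two bonds along the chain from a nitrogen on an aromatic ring. Among the measured compounds shown here, none of the three measured steps touches this part of the chain; each of them swaps the whole group on the ring nitrogen, so no measured step bears directly on the change. The expectation is therefore a step of small to modest size, a step that the limit leaves unreadable from compound 3 to compound 4, with no firm direction, and most likely a value that again only reaches the limit. On that basis compound 4 is estimated at 1500 nM, between 500 nM and 5000 nM.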

Compound 4, half-maximal effective concentration: 20 nM
The estimate for compound 4 lay 75-fold (1.88 log units) above the measured number; measured number below the stated range.
By their numbers in this assay, from the lowest: compound 4; then compound 2; then compound 1. At a limit, above all of these: compound 3.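

Replacing hydroxysulfamoyl with (dimethylsulfamoyl)methyl on this saturated chain carbon gives an at least 40-fold lower number from compound 3 to compound 4 (1.60 log units; beyond the scatter), so an open chain on the ring nitrogen is not tied to the weak end of the series, though the size of this step is only a floor, set by a limit for compound 3: the limit of > 800 nM in this assay, at which 1 of the 4 values shown sits.

The new chain also compares well with the two other groups on that nitrogen, giving a 4.0-fold lower number from compound 2 to compound 4 (0.60 log units; beyond the scatter) and a 28-fold lower number from compound 1 to compound 4 (1.44 log units; beyond the scatter), and each of these steps lies beyond the scatter. Compound 4 therefore has the lowest number of the four in this assay, and it reaches this without the four-membered ring of compound 2.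

This change brings a longer chain and a different sulfamoyl end together, so the compounds shown cannot say which of the two carries the step; 2-(dimethylsulfamoyl)ethyl or 3-(hydroxysulfamoyl)propyl would separate them. Also open, from the compounds shown here alone, is whether the dimethylsulfamoyl end itself is needed, or whether a carboxylic acid or an amine at the end of the same chain would give a similar number.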